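The source may hold more compounds than are shown below. What is called first, only, known or untested is meant among the compounds shown, and "the series" means these compounds.

Measured compounds:
- Compound 1, `CCCc1ccc2nc(N)sc2c1`, in a functional assay on the whole organism with Rattus norvegicus as the target (a higher number here means that more compound is needed for the effect, a lower number that less compound is needed), gives 6 mg/kg.
- Compound 2, `Cn1c(=N)sc2cc(OC(F)(F)F)ccc21`, in this assay gives 5 mg/kg.

Two compounds have been run in this assay. Compound 2 and compound 1 sit close together on this measure, and the gap between the two values lies within the usual scatter of repeated measurements, so the data do not separate them.

Compound 3, `N=c1sc2cc(OC(F)(F)F)ccc2n1CC(N)=O`, has not yet been measured in this assay. It is derived from compound 2 by a single change: carbamoyl in place of hydrogen on a saturated chain carbon bound to an aromatic nitrogen. Going by the values given here, no pair of measured compounds here differs by this kind of change, so there is nothing in the present numbers from which the size of the step can be read directly.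

Among the compounds with values here, with no such precedent, the expectation for compound 3 rests on the value of compound 2, 5 mg/kg, and the step from compound 2 to compound 3 is estimated as a 1.2-fold higher number from compound 2 to compound 3 (0.08 log units; within the scatter), which is not expected to exceed the scatter. Compound 3 is therefore estimated at 6 mg/kg in this assay, with a range from 2 mg/kg to 20 mg/kg.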

Compound 3, dose for half-maximal effect: 7 mg/kg
Beside the measured number, compound 3's estimate is 1.2-fold (0.07 log units) below it; the range from low to high includes it.
By their numbers in this assay, from the lowest: compounds 2, 1 and 3 (each within the scatter of the next).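

Going by these compounds alone, the one step that can be read at this position in this assay is carbamoyl in place of hydrogen on a saturated chain carbon bound to an aromatic nitrogen, which gives a 1.4-fold higher number from compound 2 to compound 3 (0.15 log units; within the scatter). Within the data shown here, until now the set held no pair differing in one place, so this is the only direct reading of how the dose responds to a change at this spot. In this single pair, methyl can give way to carbamoylmethyl, a larger group carrying a hydrogen-bond donor and a hydrogen-bond acceptor, with no shift that can be told apart from the scatter, although no measurement at hand explains this outcome.

From the compounds shown here alone, whether the same holds for other groups at this place, such as an amine, a carboxylic acid or a longer chain, remains open, as one pair cannot show how far the position's tolerance extends. Also open, going by these compounds, is whether the step would look the same on another core, since compound 1 differs from compound 2 in more than one place and adds nothing to this reading.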